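Moving a hydroxyl around on a terpyridine-like scaffold

The source may report more compounds than this note shows. Statements on the series, on what has been measured and on what is new or still open speak of the compounds shown alone.

Compound 1 `Oc1cccc(-c2cc(-c3cccc(C(F)(F)F)c3)cc(-c3ccccc3O)n2)c1` gives 13000 nM in a functional assay on DU-145 cells (Homo sapiens) for inhibition; a lower number here means a stronger inhibitor, a higher number a weaker inhibitor. Compound 2 `Oc1ccc(-c2cc(-c3cccc(C(F)(F)F)c3)cc(-c3ccccc3O)n2)cc1` reaches only the limit of the assay, > 50000 nM. The change between them is 4-hydroxyphenyl in place of 3-hydroxyphenyl on an aromatic carbon, and it gives an at least 3.8-fold higher number from compound 1 to compound 2 (0.58 log units; beyond the scatter); the step is known only as a bound, owing to the limit of > 50000 nM in this assay, at which 1 of the 3 values shown sits. Compound 3 `Oc1ccc(-c2cc(-c3ccc(OC(F)(F)F)cc3)cc(-c3cccc(O)c3)n2)cc1` gives 18100 nM in this assay, a value within the scatter of compound 1; the difference between the two cores is not broken down here. Compound 4 `Oc1ccc(-c2cc(-c3ccc(OC(F)(F)F)cc3)cc(-c3ccc(O)cc3)n2)cc1` is the same kind of change applied to compound 3, (4-hydroxyphenyl in place of 3-hydroxyphenyl on an aromatic carbon), though the group here sits meta to a 4-hydroxyphenyl group and a large group rather than meta to a 2-hydroxyphenyl group and a 3-(trifluoromethyl)phenyl group. From compound 3 to compound 4 the step is expected to resemble the earlier one, about a 3.6-fold higher number from compound 3 to compound 4 (0.56 log units; beyond the scatter), resting on the weakening seen from compound 1 to compound 2, an at least 3.8-fold higher number from compound 1 to compound 2 (0.58 log units; beyond the scatter). Compound 4 is therefore estimated at 65000 nM, between 25000 nM and 170000 nM, and may well be reported only as a limit.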

Compound 4, half-maximal inhibitory concentration: 5390 nM
For compound 4 the middle estimate is 12-fold (1.08 log units) above the measured one, outside the stated range (below it).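

In this assay, the change to 4-hydroxyphenyl in place of 3-hydroxyphenyl gives a 3.4-fold lower number from compound 3 to compound 4 (0.53 log units; beyond the scatter), so the weakening seen on the core of compound 1 did not carry over to the core of compound 3: the same change on two cores in this assay, an at least 3.8-fold higher number (0.58 log units; beyond the scatter) from compound 1 to compound 2 and a 3.4-fold lower number (0.53 log units; beyond the scatter) from compound 3 to compound 4, at least 12-fold (1.11 log units) apart, beyond the scatter of two such steps. The earlier step is known only as a bound, resting on a limit of the assay: the limit of > 50000 nM in this assay, at which 1 of the 4 values shown sits. The two cores differ in more than one place, so this pair does not show which difference turns the step around.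

The compounds shown leave open how the same change behaves on a core that differs from either of these in one place only. Also open, as far as these compounds go, is how an amine or a carboxylic acid in place of a hydroxyl would read in this assay.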